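Swapping the aryl group on the amine of a cytotoxic diterpenoid

This account rests on a few compounds, and the source may have more. Where it says the series, first, only, none or still open, it means among the compounds named here.

Measured compounds:
Compound 1, `C=C1[C@@H](OC(C)=O)C[C@@H]2[C@](C)(COC=O)[C@H](OC(C)=O)CC[C@@]2(C)[C@@H]1C[C@@H](Nc1ccccc1C(=O)O)C1=CCOC1=O`, 30800 nM
Compound 2, `C=C1[C@@H](OC(C)=O)C[C@@H]2[C@](C)(COC=O)[C@H](OC(C)=O)CC[C@@]2(C)[C@@H]1C[C@@H](Nc1cccc2ccccc12)C1=CCOC1=O`, 9750 nM
Compound 3, `C=C1[C@@H](OC(C)=O)C[C@@H]2[C@](C)(COC=O)[C@H](OC(C)=O)CC[C@@]2(C)[C@@H]1C[C@@H](Nc1ccc(OC)cc1)C1=CCOC1=O`, 24200 nM

All three share one core and differ only in the aryl group attached to the amine nitrogen. In a functional assay on MCF7 cells (Homo sapiens) for cytotoxicity, read by sulforhodamine B assay (a lower number here means a stronger inhibitor, a higher number a weaker inhibitor), compound 3 gives 24200 nM, a number close to that of compound 1 (a 1.3-fold lower number from compound 1 to compound 3 (0.10 log units; within the scatter)), while the step of a 2.5-fold higher number from compound 2 to compound 3 (0.39 log units; beyond the scatter) is modest but real. Compound 4, `C=C1[C@@H](OC(C)=O)C[C@@H]2[C@](C)(COC=O)[C@H](OC(C)=O)CC[C@@]2(C)[C@@H]1C[C@@H](Nc1cccc(F)c1)C1=CCOC1=O`, has not yet been measured; it differs from compound 3 as follows: 3-fluorophenyl in place of 4-methoxyphenyl on an amine nitrogen. Among the compounds with values here, no measured step covers this exact change, but every change of the aryl group seen so far moved this assay by a small amount, with a 3.2-fold lower number from compound 1 to compound 2 (0.50 log units; beyond the scatter) the largest. For compound 4 a step of about a 1.1-fold lower number from compound 3 to compound 4 (0.04 log units; within the scatter) is therefore expected, which would not pass the usual scatter. The estimate for compound 4 in this assay is 22000 nM, with a range from 9000 nM to 50000 nM.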

Compound 4, half-maximal inhibitory concentration: 14100 nM
Estimate against measurement, compound 4: 1.6-fold (0.19 log units) above; the range from low to high includes it.
By their numbers in this assay, from the lowest: compounds 2, 4, 3 and 1 (each within the scatter of the next, the first and the last beyond it).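

In this assay, within the data shown here, 3-fluorophenyl is the first group with a single aromatic ring to stand clearly apart from 2-carboxyphenyl, at a 2.2-fold lower number from compound 1 to compound 4 (0.34 log units; beyond the scatter), a separation that 4-methoxyphenyl did not reach. Compound 4 nevertheless cannot be told apart from either of its other neighbours, with a 1.4-fold higher number from compound 2 to compound 4 (0.16 log units; within the scatter) and a 1.7-fold lower number from compound 3 to compound 4 (0.23 log units; within the scatter), so naphthalen-1-yl and 4-methoxyphenyl, which do differ from each other, both remain within reach of this one group. No measurement shown here explains why these aryl groups behave as they do.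

Going by these compounds, what the fluorine itself contributes stays open, and plain phenyl would speak to that. It is also unclear whether an aromatic ring is needed on the amine nitrogen at all, which a cyclohexyl group or a simple alkyl chain there could test.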